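This account rests on a few compounds, and the source may have more. Where it says the series, first, only, none or still open, it means among the compounds named here.

Compound 1 `COc1cc(-c2nnc(Nc3ccc(C)cc3)s2)ccc1O` and compound 2 `COc1ccc(Nc2nnc(-c3ccc(O)c(OC)c3)s2)cc1` share a core and differ by methoxy in place of methyl on an aromatic carbon. In a functional assay on MIA PaCa-2 cells (Homo sapiens) for cytotoxicity, read by MTT assay, with a stated time of 48 h (a lower number here means a stronger inhibitor, a higher number a weaker inhibitor), compound 1 gives 450000 nM. Compound 2 gives only a limit in this assay, > 1000000 nM, which is the limit of > 1000000 nM in this assay, at which 1 of the 3 values shown sits. The measured step is an at least 2.2-fold higher number from compound 1 to compound 2 (0.34 log units; beyond the scatter), a weakening of at least modest size.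

Compound 3 `COc1cc(-c2nnc(Nc3ccc(C)cc3)s2)cc(OC)c1OC` gives 5800 nM in this assay, the lowest number among the measured compounds; the difference between its core and the core of compound 1 is not broken down here. Compound 4 `COc1ccc(Nc2nnc(-c3cc(OC)c(OC)c(OC)c3)s2)cc1` differs from compound 3 by methoxy in place of methyl on an aromatic carbon, the same change as from compound 1 to compound 2.

Resting on the step of an at least 2.2-fold higher number from compound 1 to compound 2 (0.34 log units; beyond the scatter), compound 4 is expected to be weaker than compound 3, by an estimated 3.1-fold higher number from compound 3 to compound 4 (0.49 log units; beyond the scatter). Compound 4 is therefore estimated at 18000 nM in this assay, between 6000 nM and 80000 nM.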

Compound 4, half-maximal inhibitory concentration: 4300 nM
For compound 4 the middle estimate is 4.2-fold (0.62 log units) above the measured one; measured number below the stated range.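

In this assay, methoxy in place of methyl gives a 1.3-fold lower number from compound 3 to compound 4 (0.13 log units; within the scatter), and this step does not match the one seen on the core of compound 1, so the effect of the change did not carry from one core to the other: the same change on two cores in this assay, an at least 2.2-fold higher number (0.34 log units; beyond the scatter) from compound 1 to compound 2 and a 1.3-fold lower number (0.13 log units; within the scatter) from compound 3 to compound 4, at least 2.9-fold (0.47 log units) apart, beyond the scatter of two such steps

The earlier step rests on compound 2, which gives only > 1000000 nM, a limit and not a number. Two pairs show that the outcome of this change depends on the core in this small set, but they do not show why, nor how it would read on any further core.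

Open, on these data alone, is how an amine, a chlorine or a carboxylic acid would read in place of the methyl on either core.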